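The compounds below may be only part of what the source reports. "The series", "measured", "known", "first", "only" and "open" are said of these compounds alone.

Values in a functional assay on HL-60 cells (Homo sapiens) for cytotoxicity, read by CellTiter-Blue, with a stated time of 48 h; on this read-out higher numbers stand for weaker inhibition and lower numbers for stronger inhibition:
- compound 1 `CCOC(=O)CC1C(C(=O)OCC)=C(N)Oc2ccc(-c3ccc(F)cc3)cc21`: 72100 nM
- compound 2 `CCOC(=O)CC1C(C(=O)OCC)=C(N)Oc2ccc(-c3cccs3)cc21`: > 80000 nM (a limit of the assay, not a number)
- compound 3 `CCOC(=O)CC1C(C(=O)OCC)=C(N)Oc2ccc(-c3ccncc3)cc21`: 10200 nM

Compound 3 has the lowest number of the set, and its nearest neighbour with a true number is compound 1, reached by the step of a 7.1-fold lower number from compound 1 to compound 3 (0.85 log units; beyond the scatter). The step of an at least 7.8-fold lower number from compound 2 to compound 3 (0.89 log units; beyond the scatter) points the same way. By contrast, the step of an at least 1.1-fold higher number from compound 1 to compound 2 (0.04 log units; that floor lies within the scatter) shows no difference between the two groups involved beyond the scatter.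

The next analogue is compound 4 `CCOC(=O)CC1C(C(=O)OCC)=C(N)Oc2ccc(-c3cccc(N)c3)cc21`, with 3-aminophenyl in place of pyridin-4-yl on an aromatic carbon. Among the measured compounds shown here, no measured compound carries 3-aminophenyl, so the only guide is the two steps that bring in pyridin-4-yl. Compound 4 gives that group up, so some of the gain in this assay is expected to be lost. Compound 1, which also has a carbon-only aromatic ring at this place, gives 72100 nM and marks the likely upper region, although a full return to that level is not assumed.

The expected change is a rise beyond the scatter, estimated as a 2.5-fold higher number from compound 3 to compound 4 (0.39 log units; beyond the scatter). For compound 4 the estimated value is 25000 nM, with an expected range of 9000 nM to 70000 nM.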

Compound 4, half-maximal inhibitory concentration: 20200 nM
Compound 4: middle estimate off by 1.2-fold (0.09 log units), on the high side, within the range that was stated.
By their numbers in this assay, from the lowest: compounds 3 and 4 (each within the scatter of the next); then compound 1. At a limit, above all of these: compound 2.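

In this assay, 3-aminophenyl in place of pyridin-4-yl gives a 2.0-fold higher number from compound 3 to compound 4 (0.30 log units; within the scatter), so in this small set a ring hetero atom at this place is not needed for a value in the range of compound 3. Among the rings of carbon only, the two substituted phenyl groups now give a measured difference, a 3.6-fold lower number from compound 1 to compound 4 (0.55 log units; beyond the scatter), which shows that the ring type alone does not set the value, since 3-aminophenyl and 4-fluorophenyl share that ring but differ in substituent and in where it sits. Among the compounds shown here, compound 2 carries a limit of the assay and not a number, so its step is only a floor, an at least 3.9-fold lower number from compound 2 to compound 4 (0.59 log units; beyond the scatter), and it remains the one compound of the set at that limit: the limit of > 80000 nM in this assay, at which 1 of the 4 values shown sits.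

Still open, from the compounds shown here alone, is whether the amine itself or its place on the ring carries the difference from compound 1, a question that 4-aminophenyl, 3-hydroxyphenyl or pyridin-3-yl on the same aromatic carbon would address. All four compounds also keep both ethyl esters of the shared core, which leaves open how a carboxylic acid or an amide at either ester would read in this assay.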